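A few compounds are considered here, and "the series" means these few. Any claim that something is new, unique, unknown or untested is made for them only; others in the source may bear on it.

Measured compounds:
compound 1, `O=C(N/N=C/c1ccc(Cl)cc1)c1cccnc1` — 12.5 mg/kg
compound 2, `O=C(N/N=C/c1cccc(Br)c1)c1cccnc1` — 35 mg/kg

Both compounds were tested in a functional assay on the whole organism (strain C57B/6) with Mus musculus as the target, with a stated time of 0.5 h; on this read-out lower numbers stand for an effect already at smaller amounts and higher numbers for an effect only at larger amounts of compound. For the measured compounds named here, on this read-out compound 2 gives the higher of the two numbers, and compound 1 the lower; the gap between compound 2 and compound 1 lies beyond the usual scatter of this assay, so compound 2 stands as the compound needing the larger dose among the two measured so far.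

Compound 3, `O=C(N/N=C/c1cccc(Cl)c1)c1cccnc1`, has not yet been measured. It differs from compound 2 in a single place: chloro in place of bromo on an aromatic carbon. Going by the values given here, no measured pair shows this exchange on its own, so the data give no direct size for it. The change is expected to be modest: the step from compound 2 to compound 3 is estimated as a 1.4-fold lower number from compound 2 to compound 3 (0.15 log units; within the scatter), which stays within the scatter, with a slight lean toward a lower number. Compound 3 is therefore expected to give about 25 mg/kg in this assay, within a range from 12 mg/kg to 50 mg/kg.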

Compound 3, minimum effective dose: 40 mg/kg
Compound 3: middle estimate off by 1.6-fold (0.20 log units), on the low side; low and high end bracket the measured number.
By their numbers in this assay, from the lowest: compound 1; then compounds 2 and 3 (each within the scatter of the next).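

Measured this assay, the exchange of bromo for chloro on an aromatic carbon, meta to a large group, now has a direct size (a 1.1-fold higher number from compound 2 to compound 3 (0.06 log units; within the scatter)). The earlier compounds shown here gave no such size, and this step shows that at this position the two halogens cannot be told apart on this read-out. No measurement at hand speaks to a cause of this result.

Going by these compounds, what remains open is whether a group other than these two halogens at this position, such as an amine, a methoxy group, a carboxylic acid or a longer alkyl chain, would leave the minimum effective dose where it stands or move it. Also open, on these data alone, is whether the same exchange of bromo for chloro would be equally small elsewhere on this ring.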